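This account rests on a few compounds, and the source may have more. Where it says the series, first, only, none or still open, it means among the compounds named here.

Working notes on the sulfonyl series. In a toxicity assay on Vero cells (Chlorocebus sabaeus) for cytotoxicity, read by MTT assay (on this read-out higher numbers stand for weaker inhibition and lower numbers for stronger inhibition), compound 1 (`CCOC(=O)NC(=O)c1ccsc1NC(=O)c1ccc(S(=O)(=O)N2CCC2)cc1`) gives > 64 ug/mL, which is a limit of the assay and not a number. In this assay, among the measured compounds shown here, compound 2 (`CCOC(=O)NC(=O)c1ccsc1NC(=O)c1ccc(S(=O)(=O)N2CCCC2)cc1`) gives 58.2 ug/mL, the only true number so far. Compound 3 (`CCOC(=O)NC(=O)c1ccsc1NC(=O)c1ccc(S(=O)(=O)N2CCCCCC2)cc1`) differs from compound 2 as follows: azepan-1-yl in place of pyrrolidin-1-yl on a sulfonyl sulfur. For the measured compounds named here, one measured step bears on this change, the exchange at the same sulfonyl sulfur that led to compound 2: an at least 1.0-fold lower number from compound 1 to compound 2 (0.04 log units; that floor lies within the scatter). That single step, bounded on one side only, gives no ground for expecting a shift beyond the scatter in this assay. The expected step is a 1.2-fold lower number from compound 2 to compound 3 (0.08 log units; within the scatter). For compound 3 the estimated value is 48 ug/mL, with an expected range of 22 ug/mL to 100 ug/mL.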

Compound 3, half-maximal inhibitory concentration: 3.42 ug/mL
Compound 3: the middle estimate sits 14-fold (1.15 log units) above what was measured; measured number outside the range, below it.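

In this assay, the amine ring on the sulfonyl sulfur proves able to move the read-out: azepan-1-yl gives a 17-fold lower number from compound 2 to compound 3 (1.23 log units; beyond the scatter), whereas the earlier exchange at the same sulfur gave only an at least 1.0-fold lower number from compound 1 to compound 2 (0.04 log units; that floor lies within the scatter). Among these compounds the number therefore does not fall in even steps with ring size, and the only shift that can be sized lies between the five-membered and seven-membered rings. Against azetidin-1-yl the change reads an at least 18-fold lower number from compound 1 to compound 3 (1.27 log units; beyond the scatter), but this is only a floor, because compound 1 stands at a limit of the assay: the limit of > 64 ug/mL in this assay, at which 1 of the 3 values shown sits.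

As far as these compounds go, whether the shift sets in gradually or only with azepan-1-yl stays open, and piperidin-1-yl or morpholin-4-yl on the same sulfonyl sulfur would bear on that. Also open, from the compounds shown here alone, is whether an open-chain group such as diethylamino at this sulfur would follow the same course.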